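The source may hold more compounds than are shown below. What is called first, only, known or untested is meant among the compounds shown, and "the series" means these compounds.

Of the compounds shown here, two have been measured in an assay on CHO-K1 cells for antagonist activity at transient receptor potential cation channel subfamily V member 1 (Homo sapiens), read by FLIPR and calcium flux, with a stated time of 6 min (a lower number here means a stronger inhibitor, a higher number a weaker inhibitor), so far, and both share one core that carries a tert-butyl group and a substituted phenyl ring on an aromatic nitrogen. Compound 1 `CC(C)(C)c1cc(CNC(=O)Nc2cccc3[nH]ncc23)n(-c2cccc(C(F)(F)F)c2)n1` gives 0.3 nM in this assay. Among the measured compounds shown here, compound 2 `CC(C)(C)c1cc(CNC(=O)Nc2cccc3[nH]ncc23)n(-c2ccc(C(F)(F)F)cc2)n1` gives 19.6 nM in this assay, which is the higher of the two numbers; the only measured step, a 65-fold higher number from compound 1 to compound 2 (1.82 log units; beyond the scatter), shows how far the two lie apart.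

Compound 3 `CC(C)(C)c1cc(CNC(=O)Nc2cccc3[nH]ncc23)n(-c2ccc(F)c(F)c2)n1` has not yet been measured. It differs from compound 2 in one place: 3,4-difluorophenyl in place of 4-(trifluoromethyl)phenyl on an aromatic nitrogen. For the measured compounds named here, the single step on record, from compound 1 to compound 2, touched the same phenyl ring and was large, so a change at this ring can clearly move the number. Which way a 3,4-difluorophenyl will move it is not shown by any measured pair, but since compound 1 with its 3-(trifluoromethyl)phenyl gives 0.3 nM, a step downward from compound 2 is expected, of about a 6.5-fold lower number from compound 2 to compound 3 (0.82 log units; beyond the scatter). For compound 3 the estimated value in this assay is 3 nM, with a range from 0.5 nM to 15 nM.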

Compound 3, inhibition constant: 0.5 nM
Compound 3: middle estimate off by 6.0-fold (0.78 log units), on the high side; low and high end bracket the measured number.
By their numbers in this assay, from the lowest: compounds 1 and 3 (each within the scatter of the next); then compound 2.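

In this assay, putting 3,4-difluorophenyl in place of 4-(trifluoromethyl)phenyl on the aromatic nitrogen gives a large change (a 39-fold lower number from compound 2 to compound 3 (1.59 log units; beyond the scatter)), in the opposite direction to the earlier step at this ring. This shows that a trifluoromethyl group is not required for a low number here, since compound 3 has no such group. The comparison with the other low compound (a 1.7-fold higher number from compound 1 to compound 3 (0.22 log units; within the scatter)) does not separate 3,4-difluorophenyl from 3-(trifluoromethyl)phenyl, which leaves compound 2 as the only one of the three apart from the others, while no supporting measurement bears on what lies behind these differences.

The compounds shown leave open whether a phenyl ring with a single fluorine would fall with compound 1 and compound 3 or with compound 2, and where a phenyl ring carrying a methoxy group or an amine would fall. They also say nothing about the tert-butyl group, which all three share, so the effect of a cyclopropyl group in its place remains an open question.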